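This account rests on a few compounds, and the source may have more. Where it says the series, first, only, none or still open, it means among the compounds named here.

- compound 1 `Nc1ccccc1NC(=O)c1ccc(CNCc2nc(-c3ccc(Cl)cc3)no2)cc1`: 5120 nM
- compound 2 `Nc1ccccc1NC(=O)c1ccc(CNCc2nc(-c3cccs3)no2)cc1`: 10400 nM
- compound 3 `O=C(NO)c1ccc(CNCc2nc(-c3ccccc3)no2)cc1`: 14700 nM

All three compounds were tested in a functional assay on MDA-MB-231 cells (Homo sapiens) for inhibition, read by MTT assay, with a stated time of 72 h; on this read-out higher numbers stand for weaker inhibition and lower numbers for stronger inhibition. There, compound 3 gives 14700 nM, which lies within the scatter of compound 2 at 10400 nM. The number for compound 1, 5120 nM, is lower than that of compound 3 by more than the scatter.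

The next compound, compound 4 `O=C(NO)c1ccc(CNCc2nc(-c3ccc([N+](=O)[O-])cc3)no2)cc1`, differs from compound 3 at one place, with nitro in place of hydrogen on an aromatic carbon, para to a large group: nitro in place of hydrogen on an aromatic carbon. The same difference, cut one bond further out, reads phenyl to 4-nitrophenyl.

Among the compounds with values here, only one measured step bears on this change: a 2.0-fold higher number from compound 1 to compound 2 (0.31 log units; beyond the scatter), with thiophen-2-yl in place of 4-chlorophenyl on an aromatic carbon. That step is modest, and it was measured on a different core, so it offers only indirect guidance. Within the data shown here, no measured step adds a group to the phenyl ring of compound 3 itself. A small change is therefore expected in this assay, with a slight lean towards a lower number and nothing clearly beyond the scatter. The expected step is a 1.5-fold lower number from compound 3 to compound 4 (0.17 log units; within the scatter). For compound 4 the estimated value is 10000 nM, with an expected range from 4000 nM to 25000 nM.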

Compound 4, half-maximal inhibitory concentration: 9560 nM
Estimate against measurement, compound 4: 1.0-fold (0.02 log units) above; the range from low to high includes it.
By their numbers in this assay, from the lowest: compounds 1, 4, 2 and 3 (each within the scatter of the next, the first and the last beyond it).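

In this assay, replacing phenyl with 4-nitrophenyl gives a 1.5-fold lower number from compound 3 to compound 4 (0.19 log units; within the scatter), the first step shown that changes the ring para to a large group on this core, whereas the only earlier step belonged to a different core. Nitro puts 3 heavy atoms and 2 hydrogen-bond acceptors where there was only a hydrogen, yet the two numbers remain within the scatter, so this addition produces no readable shift on the core of compound 3. Nothing measured here offers an explanation for that outcome.

The compounds shown leave open whether a smaller or hydrogen-bond-donating group at the same place, such as an amine or a hydroxyl, would also stay within the scatter, or whether a methoxy group or a longer chain would move the number beyond it. They also leave open whether nitro would behave in the same way on the core of compound 1, where the ring carries chlorine or is replaced by thiophene.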